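A swap of halogens for methyls on the aryl ring

A few compounds are considered here, and "the series" means these few. Any claim that something is new, unique, unknown or untested is made for them only; others in the source may bear on it.

The series shares one core, carried by compound 1 `Cc1oc(-c2c(F)cccc2F)nc1CN1CCC(C(=O)NCCCN2C[C@H](C)C[C@H](C)C2)CC1`, by compound 2 `CC[C@@H]1C[C@H](CC)CN(CCCNC(=O)C2CCN(Cc3nc(-c4c(F)cccc4F)oc3C)CC2)C1`, by compound 3 `Cc1cccc(Cl)c1-c1nc(CN2CCC(C(=O)NCCCN3CCC(C(C)C)CC3)CC2)c(C)o1` and by the still unmeasured compound 4 `Cc1cccc(C)c1-c1nc(CN2CCC(C(=O)NCCCN3C[C@H](C)C[C@H](C)C3)CC2)c(C)o1`. In a physicochemical assay for permeability, using PAMPA (a higher number here means that the compound crosses the layer faster, a lower number that the compound crosses the layer more slowly), compound 1 gives 82.4 10^-6 cm/s, and compound 2 gives 130 10^-6 cm/s. In this assay compound 3 gives "not determined" (no result reported), so no number is at hand for it. Among the two numbers at hand, compound 1 stands lowest, with compound 2 the nearest neighbour: the step of a 1.6-fold higher number from compound 1 to compound 2 (0.20 log units; within the scatter) is within the scatter, so no order between these two is claimed.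

Compound 4 differs from compound 1 in one place: 2,6-dimethylphenyl in place of 2,6-difluorophenyl on an aromatic carbon. Among the measured compounds shown here, the only measured step, the one from compound 1 to compound 2, concerns the 3,5-diethylpiperidin-1-yl in place of the 3,5-dimethylpiperidin-1-yl group and does not touch the aryl ring, so it offers no direct guide to this change. For the measured compounds named here, with both groups counted as equal in heavy atoms and in donors and acceptors, and no measured step for this exchange, the expected step of a 1.1-fold higher number from compound 1 to compound 4 (0.04 log units; within the scatter) is taken to lie within the scatter. Compound 4 is therefore estimated at 90 10^-6 cm/s in this assay, with a range from 45 10^-6 cm/s to 180 10^-6 cm/s.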

Compound 4, apparent permeability: 254 10^-6 cm/s
The estimate for compound 4 lay 2.8-fold (0.45 log units) below the measured number; the whole stated range lies below it.
By their numbers in this assay, from the lowest: compounds 1, 2 and 4 (each within the scatter of the next, the first and the last beyond it).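

In this assay, among the compounds shown here, the exchange of 2,6-difluorophenyl for 2,6-dimethylphenyl on an aromatic carbon of the shared core gives a 3.1-fold higher number from compound 1 to compound 4 (0.49 log units; beyond the scatter), so this aryl position is the first place where a single change produces a step beyond the scatter. For the compounds shown here, the only earlier step, a 1.6-fold higher number from compound 1 to compound 2 (0.20 log units; within the scatter), concerned the substituted piperidine at the other end of the molecule and left this open. The two aryl groups match in heavy atoms, hydrogen-bond donors and acceptors, and net charge, so those counts do not separate them, and nothing measured here accounts for the step, which therefore stands as an observation without an assigned cause.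

The compounds shown leave open whether the step carries over to the 3,5-diethylpiperidin-1-yl partner of compound 2, since that group never appears with 2,6-dimethylphenyl, and compound 3, the only other aryl variant, has no number and also differs in its piperidine. They also leave open where a 2,6-dichlorophenyl or an unsubstituted phenyl group would fall relative to the two aryl groups compared here.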